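Fluorine Swap on a Diene Biaryl Core: Cytotoxicity Outlook

The compounds below may be only part of what the source reports. "The series", "measured", "known", "first", "only" and "open" are said of these compounds alone.

Measured compounds:
compound 1 `C=C[C@@](C)(/C=C/c1ccc(Nc2cc(F)cc(F)c2)cc1)CCC=C(C)C`: > 36600 nM
compound 2 `C=C[C@@](C)(/C=C/c1ccc(Nc2cc(F)c(F)c(F)c2)cc1)CCC=C(C)C`: > 36600 nM
compound 3 `C=C[C@@](C)(/C=C/c1ccc(-c2ccccc2)cc1)CCC=C(C)C`: > 36600 nM

Three compounds built on a shared core were tested in a functional assay on SEM cells (Homo sapiens) for cytotoxicity, with a stated time of 72 h; a lower number here means that less compound is needed, a higher number that more compound is needed for the effect. Compound 1 gives > 36600 nM, which is a limit of the assay and not a number. Compound 2 likewise gives only a limit, > 36600 nM. Compound 3 also stops at a limit, > 36600 nM. The change from compound 1 to compound 2 is fluoro in place of hydrogen on an aromatic carbon, and its step that the two limits leave unreadable from compound 1 to compound 2 cannot be sized because every value sits at the limit of > 36600 nM in this assay, at which 3 of the 3 values shown sit. Compound 3 differs from compound 1 by phenyl in place of (3,5-difluorophenyl)amino on an aromatic carbon, and the step that the two limits leave unreadable from compound 1 to compound 3 is equally unreadable.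

Compound 4 `C=C[C@@](C)(/C=C/c1ccc(-c2ccc(F)cc2)cc1)CCC=C(C)C` is not yet measured. It differs from compound 3 by fluoro in place of hydrogen on an aromatic carbon. This is the same kind of change as that from compound 1 to compound 2, though there the place was ortho to two fluoro groups as well as para to a large group, while here it is para to a large group only. The step that the limit leaves unreadable from compound 3 to compound 4 is expected to be small, since the earlier change of this kind left no readable step that the two limits leave unreadable from compound 1 to compound 2. Compound 4 is therefore expected to give about 40000 nM, between 15000 nM and 100000 nM, with another limit the likeliest outcome.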

Compound 4, half-maximal effective concentration: > 36600 nM
Compound 4 ended at the assay's limit; the forecaster's own chance of this, stated with the estimate: 85%; the middle value is on the limit's open side.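

No step from compound 3 to compound 4, or from compound 1 to compound 4, can be read, because each value is a limit of the assay and not a number: the limit of > 36600 nM in this assay, at which 4 of the 4 values shown sit.

The compounds shown leave open where any of their true values lies, and so whether the change from phenyl to 4-fluorophenyl has any effect at all.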